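Removing a Methyl from the Core and Cell Tolerance

This account rests on a few compounds, and the source may have more. Where it says the series, first, only, none or still open, it means among the compounds named here.

Compound 2 `CCN(CC)CC(=O)Nc1ccc(-c2nc3cc(C(F)(F)F)ccc3n2C)cc1` was measured in an ADME assay on MDBK cells (Bos taurus) for cytotoxicity, read by MTT assay, with a stated time of 96 h (a higher number here means that more compound is tolerated, a lower number that less compound is tolerated), where compound 2 gives 57000 nM. Among the compounds with values here, this is the only plain number available here; the one other result is a limit rather than a number. Compound 1 `O=C(O)CCC(=O)Nc1ccc(-c2nc3cc(C(F)(F)F)ccc3[nH]2)cc1` gives > 100000 nM in this assay, a limit of the assay and not a measured number. That result sits at the limit of > 100000 nM in this assay, at which 1 of the 2 values shown sits. Compound 3 `CCN(CC)CC(=O)Nc1ccc(-c2nc3cc(C(F)(F)F)ccc3[nH]2)cc1` has not yet been tested in this assay. It differs from compound 2 in one place: hydrogen in place of methyl on an aromatic nitrogen. Within the data shown here, no step between two measured compounds shows what this change does to cell tolerance, so any expectation rests on the two results alone. Compound 3 is expected to lean toward the better-tolerated side, with an estimated step of a 1.4-fold higher number from compound 2 to compound 3 (0.15 log units; within the scatter), though such a shift may well lie within the usual scatter. Compound 3 is therefore estimated at 80000 nM in this assay, in a range from 30000 nM to 200000 nM.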

Compound 3, half-maximal cytotoxic concentration: 13000 nM
Beside the measured number, compound 3's estimate is 6.2-fold (0.79 log units) above it, outside the stated range (below it).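

In this assay, hydrogen in place of methyl on the aromatic nitrogen gives a 4.4-fold lower number from compound 2 to compound 3 (0.64 log units; beyond the scatter), so this very small change does alter how well the cells tolerate the compound. With that hydrogen in place, diethylamino in place of carboxymethyl gives an at least 7.6-fold lower number from compound 1 to compound 3 (0.88 log units; beyond the scatter), so the group on the chain also affects tolerance. Compound 1 stands at a limit of the assay, so this second step has no exact size: the limit of > 100000 nM in this assay, at which 1 of the 3 values shown sits.

The compounds shown do not tell why the methyl makes this difference, or whether an ethyl or a longer chain on that nitrogen would shift the number the same way. They also leave open whether the methyl has the same effect with the chain of compound 1, or with a primary amine in place of diethylamino.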